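A few compounds are considered here, and "the series" means these few. Any claim that something is new, unique, unknown or untested is made for them only; others in the source may bear on it.

In an assay on HEK293 cells for displacement of a labelled ligand from NPC1-like intracellular cholesterol transporter 1 (Homo sapiens) (on this read-out higher numbers stand for weaker inhibition and lower numbers for stronger inhibition), compound 3 `CC(C)(C)c1ccc(C(=O)N2CCC3(CC2)C(=O)N(CC(=O)NCCCCCO)CN3c2ccccc2)cc1` gives 9400 nM, placing it toward the weak end of the three numbers here. Compound 1 `CC(C)(C)c1ccc(C(=O)N2CCC3(CC2)C(=O)N(CC(=O)NCCC(=O)O)CN3c2ccccc2)cc1` gives 11400 nM, and a 1.2-fold lower number from compound 1 to compound 3 (0.08 log units; within the scatter). Compound 2 `CC(C)(C)c1ccc(C(=O)N2CCC3(CC2)C(=O)N(CC(=O)N2CCC(CCO)CC2)CN3c2ccccc2)cc1` gives 2600 nM, and a 3.6-fold higher number from compound 2 to compound 3 (0.56 log units; beyond the scatter). Compound 4 `CC(C)(C)c1ccc(C(=O)N2CCC3(CC2)C(=O)N(CC(=O)N2CCCCC2CCO)CN3c2ccccc2)cc1` differs from compound 3 by 2-(2-hydroxyethyl)piperidin-1-yl in place of (5-hydroxypentyl)amino on a carbonyl carbon. Going by the values given here, two measured steps bear on this: a 3.6-fold higher number from compound 2 to compound 3 (0.56 log units; beyond the scatter), and a 4.4-fold lower number from compound 1 to compound 2 (0.64 log units; beyond the scatter), in which 4-(2-hydroxyethyl)piperidin-1-yl replaced an open-chain amide group. Both show that closing the hydroxyalkyl amine into a piperidine gave a modestly lower number, so a modest lowering is expected here too, a 2.7-fold lower number from compound 3 to compound 4 (0.43 log units; beyond the scatter). Compound 4 is therefore estimated at 3500 nM, with a range from 1500 nM to 8000 nM.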

Compound 4, half-maximal inhibitory concentration: 6100 nM
Estimate against measurement, compound 4: 1.7-fold (0.24 log units) below, and the stated range covers the measured number.
By their numbers in this assay, from the lowest: compound 2; then compounds 4, 3 and 1 (each within the scatter of the next).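

A piperidine ring alone does not account for the gain seen with compound 2: a 1.5-fold lower number from compound 3 to compound 4 (0.19 log units; within the scatter) and a 1.9-fold lower number from compound 1 to compound 4 (0.27 log units; within the scatter) both stay within the scatter. Where the 2-hydroxyethyl chain sits on the ring does count, since a 2.3-fold higher number from compound 2 to compound 4 (0.37 log units; beyond the scatter) lies beyond the scatter. Nothing measured here explains this difference. Still open, as far as these compounds go, is whether a 4-(2-hydroxyethyl)piperidin-1-yl group with a longer chain, or with an amine or a carboxylic acid instead of its hydroxyl, would match the value of compound 2 (2600 nM).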